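Aryloxypropoxy series, halogen swap on the phenyl ether

The source may report more compounds than this note shows. Statements on the series, on what has been measured and on what is new or still open speak of the compounds shown alone.

Working notes on the series. Compound 2 `NC1=NC2(CCOCC2)N(OCCCOc2ccc(Cl)cc2)C(N)=N1` is the reference point for the present step. In an assay on isolated protein for inhibition of Dihydrofolate reductase (Homo sapiens), read by spectrophotometry, using NADPH, with stated times of 5 s and 6 min, tested at 50 uM (a higher number here means a stronger effect of the compound at the concentration tested, a lower number a weaker effect), compound 2 gives "not determined" (no result reported), so there is no single number on which compound 2 stands. Among the measured compounds shown here, the only numbers come from two compounds that share the propoxy linker and the aryl ether but differ from compound 2 in the shared core: compound 1 `CC(C)(C)c1ccc(OCCCON2C(N)=NC(N)=NC23CCSCC3)cc1` gives 86.6% in this assay, and compound 3 `NC1=NC2(CCSCC2)N(OCCCOc2ccccc2Br)C(N)=N1` gives 89.6%. These two values lie within the scatter of each other; no order between them is claimed.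

Compound 4 `NC1=NC2(CCOCC2)N(OCCCOc2cccc(Br)c2)C(N)=N1` is not yet measured. It differs from compound 2 by 3-bromophenyl in place of 4-chlorophenyl on an oxygen on a saturated carbon. For the measured compounds named here, no measured pair in the set isolates this change, so the size of the step in this assay is unknown. Given that compound 1 and compound 3 both sit high with different aryl substituents, compound 4 is expected to land in the same high region, estimated at 85% with a range of 65% to 95%.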

Compound 4, a percentage reported as inhibition, at one concentration (the size of the read-out at that concentration, not a potency): 85.8%
Compound 4: the middle estimate sits 0.8 percentage points below what was measured; low and high end bracket the measured number.
By their numbers in this assay, from the lowest: compounds 4, 1 and 3 (each within the scatter of the next).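

No step can be read from the result for compound 4, as compound 2 offers no single number to set against it. The compounds shown leave open how 3-bromophenyl compares with 4-chlorophenyl on the shared core. No evidence at hand bears on this result.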